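The source may hold more compounds than are shown below. What is called first, only, known or untested is meant among the compounds shown, and "the series" means these compounds.

Measured compounds:
Compound 1 `Cc1ncnc2c1c(-c1ccoc1)cn2[C@@H]1O[C@H](CO)[C@@H](O)[C@H]1O`: 98300 nM
Compound 2 `CSc1ncnc2c1c(-c1cccs1)cn2[C@@H]1O[C@H](CO)[C@@H](O)[C@H]1O`: > 100000 nM

Both results come from an ADME assay on MRC5 cells (Homo sapiens), read by MTT assay, with a stated time of 72 h; on this read-out higher numbers stand for weaker inhibition and lower numbers for stronger inhibition. In this assay compound 1 gives 98300 nM. For compound 2 the result in this assay is > 100000 nM, which is a limit of the assay and not a number, as marked by the limit of > 100000 nM in this assay, at which 1 of the 2 values shown sits. Compound 2 thus stands at the upper edge of what this assay reports, with only a limit on record. Compound 3 `CSc1ncnc2c1c(-c1ccoc1)cn2[C@@H]1O[C@H](CO)[C@@H](O)[C@H]1O` has not been measured. It differs from compound 2 in one place: furan-3-yl in place of thiophen-2-yl on an aromatic carbon. Among the measured compounds shown here, no pair of measured compounds differs in a single place, so no measured step sizes this change; what can be said is that compound 1, which also carries the furan-3-yl, gives 98300 nM. Compound 3 is therefore expected to show no step beyond the usual scatter, a number no higher from compound 2 to compound 3 (the limit leaves the size open). The estimate for compound 3 in this assay is 100000 nM, between 50000 nM and 200000 nM, with a fair chance that only a limit is reported again.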

Compound 3, half-maximal inhibitory concentration: > 100000 nM
Compound 3: no number, only a limit; the forecaster's own chance of this, stated with the estimate: 60%; the middle value sits exactly at the limit.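

With the furan-3-yl held fixed, methylsulfanyl in place of methyl on an aromatic carbon gives, in this assay, an at least 1.0-fold higher number from compound 1 to compound 3 (0.00 log units; that floor lies within the scatter), so this pair shows only a floor and no change that can be told from the scatter. The result for compound 3 is a limit of the assay and not a number, as is the result for compound 2, so the step for furan-3-yl in place of thiophen-2-yl cannot be read. The new result adds one more compound to those held at this limit: the limit of > 100000 nM in this assay, at which 2 of the 3 values shown sit.

On these data alone, how far compound 3 and compound 2 really lie past the limit stays open, and so does any difference between furan-3-yl and thiophen-2-yl. Also open, as far as these compounds go, is whether an amine or a longer chain in place of the methylsulfanyl would give a readable number in this assay.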